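Working notes: chloro for methoxy on the aryl substituent

A few compounds are considered here, and "the series" means these few. Any claim that something is new, unique, unknown or untested is made for them only; others in the source may bear on it.

Measured so far:
compound 1, `COC(=O)c1ccc(-c2nnc(SC3=CS(=O)(=O)c4ccccc43)o2)cc1`: 4000 nM
compound 2, `COc1cccc(-c2nnc(SC3=CS(=O)(=O)c4ccccc43)o2)c1`: 3000 nM
compound 3, `COc1ccccc1-c1nnc(SC2=CS(=O)(=O)c3ccccc32)o1`: 3000 nM

In an ADME assay on HEK293 cells (Homo sapiens) for cytotoxicity, read by fluorescence and resazurin assay, with a stated time of 24 h (a lower number here means that less compound is tolerated, a higher number that more compound is tolerated), compound 3 gives 3000 nM. It stands level with compound 2 at the digits shown, and the two together are the lowest of the three numbers; compound 1 gives 4000 nM, a higher number that still sits within the scatter of compound 3. Among the measured compounds shown here, the one single-point step is no change at the digits printed from compound 2 to compound 3 (within the scatter), so shifting the methoxy within the six-membered aromatic ring of carbon only left this assay unmoved.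

Compound 4 is `O=S1(=O)C=C(Sc2nnc(-c3ccccc3Cl)o2)c2ccccc21`. It differs from compound 3 by chloro in place of methoxy on an aromatic carbon. For the measured compounds named here, no measured step exchanges methoxy for chloro, so the only guidance is indirect: the one change made so far on the same six-membered aromatic ring of carbon only, from compound 2 to compound 3, did not shift the number beyond the scatter, and all three numbers lie close together. The expectation for compound 4 is therefore a step of no change at the digits printed from compound 3 to compound 4 (within the scatter), that is, none beyond the scatter. Compound 4 is estimated at 3000 nM, with a range of 1500 nM to 6000 nM.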

Compound 4, half-maximal cytotoxic concentration: 4000 nM
Beside the measured number, compound 4's estimate is 1.3-fold (0.12 log units) below it; measured number inside the range.
By their numbers in this assay, from the lowest: compounds 2, 3, 1 and 4 (each within the scatter of the next).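

In this assay the exchange of methoxy for chloro on an aromatic carbon ortho to a large group gives a 1.3-fold higher number from compound 3 to compound 4 (0.12 log units; within the scatter) and so does not separate the two groups, which extends the earlier picture from a methoxy that changes place to a different group at this position. The wider comparison, 2-chlorophenyl in place of 3-methoxyphenyl, gives a 1.3-fold higher number from compound 2 to compound 4 (0.12 log units; within the scatter) and likewise stays inside the scatter, so neither the one-atom chloro nor the loss of the methoxy oxygen as a hydrogen-bond acceptor comes with a readable shift in this cytotoxicity read-out. Nothing measured here accounts for this flat response, and no explanation can be offered for it.

The compounds shown leave open whether this flat response holds for groups of a different kind on the same ring, such as an amine, a carboxylic acid or a longer chain. They also leave open how much of the read-out belongs to the shared core, which stays the same in all four compounds while only the aryl substituent varies.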